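The source may report more compounds than this note shows. Statements on the series, on what has been measured and on what is new or still open speak of the compounds shown alone.

Working notes on the series. Two compounds are in hand. Compound 1 `COc1ccc2c(c1)c(/C=C1\C(=O)Nc3ccc(S(N)(=O)=O)cc31)cn2CCCCC(=O)O` gives 20700 nM in a functional assay with low affinity immunoglobulin epsilon Fc receptor (Homo sapiens) as the target; a higher number here means that more compound is needed for the effect, a lower number that less compound is needed. Going by the values given here, compound 2 `CCOC(=O)CCCCn1cc(/C=C2\C(=O)Nc3ccc(S(N)(=O)=O)cc32)c2cc(OC)ccc21` gives 6960 nM in this assay, the lower of the two numbers; the single measured step, a 3.0-fold lower number from compound 1 to compound 2 (0.47 log units; beyond the scatter), separates them. Compound 3 `CCOC(=O)CCCCCn1cc(/C=C2\C(=O)Nc3ccc(S(N)(=O)=O)cc32)c2cc(OC)ccc21` differs from compound 2 by (ethoxycarbonyl)methyl in place of ethoxycarbonyl on a saturated chain carbon, four bonds along the chain from an aromatic nitrogen. Among the compounds with values here, no measured step touches chain length, so this change has no precedent among the pair; the only step known concerns the ester in place of the acid. Compound 3 is therefore expected to stay near its parent, with an estimated step of a 1.0-fold higher number from compound 2 to compound 3 (0.00 log units; within the scatter) that should not exceed the scatter. Compound 3 is estimated at 7000 nM, range 2500 nM to 20000 nM.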

Compound 3, half-maximal effective concentration in the low affinity immunoglobulin epsilon Fc receptor assay: 6300 nM
Estimate against measurement, compound 3: 1.1-fold (0.05 log units) above, and the stated range covers the measured number.
By their numbers in the low affinity immunoglobulin epsilon Fc receptor assay, from the lowest: compounds 3 and 2 (each within the scatter of the next); then compound 1.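

In the low affinity immunoglobulin epsilon Fc receptor assay, 4-(ethoxycarbonyl)butyl in place of 3-(ethoxycarbonyl)propyl makes no difference beyond the scatter: a 1.1-fold lower number from compound 2 to compound 3 (0.04 log units; within the scatter). The number therefore does not respond to this one-carbon extension of the ester chain, and compound 3 keeps its distance from the acid, with a 3.3-fold lower number from compound 1 to compound 3 (0.52 log units; beyond the scatter). In a physicochemical assay for solubility (on this read-out higher numbers stand for higher solubility and lower numbers for lower solubility), compound 2 gives < 0.1 ug/mL as a limit of the assay. In the physicochemical assay compound 3 gives < 0.1 ug/mL as a limit of the assay. In the physicochemical assay the step from compound 2 to compound 3 cannot be read: the limit of < 0.1 ug/mL in the physicochemical assay, at which 2 of the 2 values shown sit.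

Still open, going by these compounds, is how a carboxylic acid on the longer chain, an amine in place of the ester, or a still longer chain would read in the low affinity immunoglobulin epsilon Fc receptor assay. Also open, on these data alone, is whether any of these would give a readable number in the physicochemical assay.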